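The source may report more compounds than this note shows. Statements on the series, on what has been measured and on what is new or still open speak of the compounds shown alone.

Measured compounds:
compound 1, `Cc1ccccc1Nc1nc(NCc2ccco2)ncc1Cl`: > 100000 nM
compound 2, `CN1CCN(c2ccc(Nc3ncc(Cl)c(NCc4ccc(F)cc4)n3)nc2)CC1`: 19300 nM

In a functional assay on MCF7 cells (Homo sapiens) for inhibition, read by CCK-8 assay, with a stated time of 48 h (a higher number here means a weaker inhibitor of growth, a lower number a stronger inhibitor of growth), compound 1 gives only > 100000 nM, which is a limit of the assay and not a number. Among the compounds with values here, compound 2 gives 19300 nM and is the sole compound with an actual number in this assay. The value of compound 1 is a limit, as the limit of > 100000 nM in this assay, at which 1 of the 2 values shown sits, records. Within the data shown here, no step between two measured compounds exists, so there is no measured step to lean on. Compound 3, `CC(C)c1cccc(Nc2nc(Nc3ccc(N4CCN(C)CC4)cn3)ncc2Cl)c1`, is not yet measured; it differs from compound 2 by 3-isopropylphenyl in place of 4-fluorobenzyl on a nitrogen on an aromatic ring. The change puts 3-isopropylphenyl in place of 4-fluorobenzyl on a nitrogen on an aromatic ring whose other neighbours are aromatic carbon. Among the measured compounds shown here, with no measured step of this kind, the expectation is a modest move toward stronger growth inhibition in this assay, near the edge of the scatter, expected as a 2.8-fold lower number from compound 2 to compound 3 (0.44 log units; beyond the scatter). Compound 3 is therefore estimated at 7000 nM, within 1500 nM to 30000 nM.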

Compound 3, concentration for 50% growth inhibition: 8640 nM
Compound 3: middle estimate off by 1.2-fold (0.09 log units), on the low side, within the range that was stated.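

In this assay, the group on a nitrogen on an aromatic ring now has a first measured effect: 3-isopropylphenyl in place of 4-fluorobenzyl gives a 2.2-fold lower number from compound 2 to compound 3 (0.35 log units; beyond the scatter). The step is modest, so at this position the (3-isopropylphenyl)amino group keeps the growth inhibition seen with the (4-fluorobenzyl)amino group and adds a little to it. Nothing measured here accounts for the step.

This single step changes the benzyl to a phenyl, removes the fluorine and adds the isopropyl all at once, and the compounds shown do not separate these three changes. Also open, from the compounds shown here alone, is how the number would respond to an amine or a carboxylic acid in place of the isopropyl, or to a longer chain on the same nitrogen.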